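The compounds below may be only part of what the source reports. "The series", "measured", "known", "first", "only" and "open" are said of these compounds alone.

Measured compounds in a functional assay on MCF7 cells (Homo sapiens) for cytotoxicity, read by MTT assay, with a stated time of 72 h (on this read-out higher numbers stand for weaker inhibition and lower numbers for stronger inhibition), are these
- compound 1 `Cn1ccc2c(Oc3ccc(NC(=O)c4cc5cccnc5n(-c5ccccc5)c4=O)cc3F)ncnc21` with 73400 nM
- compound 2 `Cn1ccc2c(Oc3ccc(NC(=O)c4cc5cccnc5n(-c5ccc(C(F)(F)F)c(Cl)c5)c4=O)cc3F)ncnc21` with "not active" (no number reported)

Among the measured compounds shown here, compound 1 holds the only number so far in this assay (73400 nM). Compound 2 gave no number, so no comparison within the series is possible.

Next comes compound 3 `O=C(Nc1ccc(Oc2ncnc3[nH]ccc23)c(F)c1)c1cc2cccnc2n(-c2ccccc2)c1=O`, which differs from compound 1 as follows: hydrogen in place of methyl on an aromatic nitrogen. For the measured compounds named here, no measured step shows what this change does, so the expectation is loose. A moderate move toward stronger inhibition is expected, though a result within the scatter of compound 1 would be no surprise. The expected change is a 2.4-fold lower number from compound 1 to compound 3 (0.39 log units; beyond the scatter) in this assay as estimated here. For compound 3 the estimated value is 30000 nM, with an expected range from 6000 nM to 100000 nM.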

Compound 3, half-maximal inhibitory concentration: 45000 nM
For compound 3 the middle estimate is 1.5-fold (0.18 log units) below the measured one, within the range that was stated.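

In this assay, hydrogen in place of methyl on the aromatic nitrogen gives a 1.6-fold lower number from compound 1 to compound 3 (0.21 log units; within the scatter), so this single step does not separate the two compounds. The methyl on this nitrogen is therefore not required for a measurable number here, and the free nitrogen-hydrogen form of the shared core remains a usable comparison point for further changes at this position. Nothing available explains the outcome of this step.

Still open, going by these compounds, is whether an ethyl group, or a longer chain ending in an amine or a carboxylic acid, on this nitrogen would also stay within the scatter of compound 1. Also open, on these data alone, is whether the same exchange behaves alike when the phenyl group of compound 1 carries other substituents, since compound 2 offers no number for comparison.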